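The source may report more compounds than this note shows. Statements on the series, on what has been measured and on what is new or still open speak of the compounds shown alone.

Compound 1, with the structure `Cc1cccc(Cn2c(CN3CCN(C(=O)c4ccc(C(C)C)cc4)CC3)nc3ccccc32)c1`, is the reference point of this account. In an assay on isolated protein for inhibition of aldehyde dehydrogenase 1A1 (Homo sapiens), read by spectrophotometry, tested at 10 uM (on this read-out lower numbers stand for less inhibition and higher numbers for more inhibition at the one concentration tested (going by the name of the read-out)), compound 1 gives 67.6%, the highest of the three numbers measured. The next nearest is compound 3, `O=C(C1CC1)N1CCN(Cc2nc3ccccc3n2CC2CCCC2)CC1`, which in this assay gives 44.5%, and the furthest is compound 2, `CCCCn1c(CN2CCN(C(=O)C3CC3)CC2)nc2ccccc21`, which in this assay gives 18.2%. Within the data shown here, the only measured step between compounds that differ in one place is a number 26.3 percentage points higher from compound 2 to compound 3 (beyond the scatter), cyclopentyl in place of propyl on a saturated chain carbon bound to an aromatic nitrogen.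

Compound 4, `CCCC(=O)N1CCN(Cc2nc3ccccc3n2Cc2cccc(C)c2)CC1`, has not yet been measured. It differs from compound 1 in one place: propyl in place of 4-isopropylphenyl on a carbonyl carbon. Among the measured compounds shown here, no measured step touches the carbonyl carbon, so the one step that exists, from compound 2 to compound 3, concerns a different part of the shared core and bears on this change only indirectly. Compounds 2 and 3 both carry a smaller group than 4-isopropylphenyl on that carbonyl carbon and both show lower numbers than compound 1, but they also differ from compound 1 elsewhere, so their values do not isolate the effect. On that slender basis a fall beyond the scatter is expected, a number 32.6 percentage points lower from compound 1 to compound 4 (beyond the scatter). Compound 4 is therefore estimated to give 35% in this assay, with a range from 15% to 58%.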

Compound 4, a percentage reported as inhibition, at one concentration (the size of the read-out at that concentration, not a potency): 79.1%
Estimate against measurement, compound 4: 44.1 percentage points below; the whole stated range lies below it.
By their numbers in this assay, from the lowest: compound 2; then compound 3; then compound 1; then compound 4.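

In this assay the carbonyl carbon proves open to a large change: replacing 4-isopropylphenyl with propyl gives a number 11.5 percentage points higher from compound 1 to compound 4 (beyond the scatter). Among these compounds, until this pair, no measured step touched this position, and it now shows that the aromatic ring of the 4-isopropylphenyl group is not required for inhibition at the one concentration tested, since a smaller group with no ring reads higher with the rest of compound 1 held constant. No measurement at hand gives a reason for the rise.

Going by these compounds, this single pair cannot show whether the number depends on chain length or on the absence of a ring, and how a plain phenyl, a longer chain such as hexyl, or a chain ending in an amine or a carboxylic acid would read on this carbonyl carbon stays open. Also open, on these data alone, is whether the step would keep its direction and size with a group other than the one carried on the aromatic nitrogen of compound 1, and whether the stronger effect at the one concentration tested would also appear at other concentrations.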